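Growth inhibition after a change of aryl group

This account rests on a few compounds, and the source may have more. Where it says the series, first, only, none or still open, it means among the compounds named here.

In a functional assay on HL-60 cells (Homo sapiens) for inhibition, read by MTT assay, with a stated time of 48 h, tested at 10 uM (on this read-out lower numbers stand for less inhibition of growth and higher numbers for more inhibition of growth at the one concentration tested), compound 1 (`Cc1oc2c([C@H]3CCN(C)C[C@H]3O)c(O)cc(O)c2c(=O)c1C(O)c1ccc(F)c(Br)c1`) gives 25% and compound 2 (`Cc1oc2c([C@H]3CCN(C)C[C@H]3O)c(O)cc(O)c2c(=O)c1C(O)c1c(F)cccc1Cl`) gives 49%, so compound 2 stands highest of the two. Compound 3 (`Cc1oc2c([C@H]3CCN(C)C[C@H]3O)c(O)cc(O)c2c(=O)c1C(O)c1cc(F)cc(F)c1`) differs from it in one place: 3,5-difluorophenyl in place of 2-chloro-6-fluorophenyl on a saturated chain carbon bound to an aromatic carbon and an oxygen on a saturated carbon. For the measured compounds named here, the only measured step at this place is a number 24 percentage points higher from compound 1 to compound 2 (beyond the scatter), and it favours the 2-chloro-6-fluorophenyl group, which compound 3 gives up. A fall of somewhat smaller size is therefore expected, an estimated a number 16 percentage points lower from compound 2 to compound 3 (beyond the scatter). For compound 3 the expected value in this assay is 33%, with an estimated range of 15% to 52%.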

Compound 3, percent growth inhibition at one concentration: 30%
Compound 3: middle estimate off by 3 percentage points, on the high side, and the stated range covers the measured number.
By their numbers in this assay, from the lowest: compounds 1 and 3 (each within the scatter of the next); then compound 2.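

In this assay the change shows a number 19 percentage points lower from compound 2 to compound 3 (beyond the scatter) and so the higher number of compound 2 is not shared by the other two halogenated phenyl groups shown at this place. The second step reads a number 5 percentage points higher from compound 1 to compound 3 (within the scatter) and so 3,5-difluorophenyl and 3-bromo-4-fluorophenyl cannot be told apart here, leaving 2-chloro-6-fluorophenyl alone beyond the scatter of both. Nothing given accounts for this difference. As far as these compounds go, it remains open how an unsubstituted phenyl, a pyridine ring or a phenyl carrying an amine or a carboxylic acid would compare at this place.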